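Notes on the step from compound 3 to compound 4

A few compounds are considered here, and "the series" means these few. Any claim that something is new, unique, unknown or untested is made for them only; others in the source may bear on it.

Values so far in a functional assay on SMMC-7721 cells (Homo sapiens) for antiproliferative activity, read by MTT assay, with a stated time of 48 h; a higher number here means a weaker inhibitor, a lower number a stronger inhibitor:
Compound 1 `COC/C1=C/C[C@](C)(CCC=C(C)C)/C=C/[C@@H](OC(=O)C=C(C)C)[C@](C)(OC)/C=C/C1=O` gives 9380 nM
Compound 2 `CC(C)=CCC[C@]1(C)/C=C/[C@@H](OC(=O)C=C(C)C)[C@](C)(O)/C=C/C(=O)/C(C(=O)O)=C\C1` gives > 10000 nM (a limit of the assay, not a number)
Compound 3 `CCN(CC)C/C1=C/C[C@](C)(CCC=C(C)C)/C=C/[C@@H](OC(=O)C=C(C)C)[C@](C)(O)/C=C/C1=O` gives 570 nM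

In this assay compound 3 at 570 nM is the lower of the two numbers, and compound 1 at 9380 nM lies beyond the scatter from it. For the measured compounds named here, compound 4 `CC(C)=CCC[C@]1(C)/C=C/[C@@H](OC(=O)C=C(C)C)[C@](C)(O)/C=C/C(=O)/C(COC(=O)c2ccc([N+](=O)[O-])cc2)=C\C1` carries ((4-nitrophenyl)carbonyl)oxy in place of diethylamino on a saturated chain carbon bound to a double-bonded ring carbon as its only change.

Going by the values given here, only one measured step bears on this: an at least 17-fold lower number from compound 2 to compound 3 (1.24 log units; beyond the scatter) (large, and a bound rather than an exact size). It brought the diethylamino group in, whereas compound 4 loses it. Compound 1 also lacks the diethylamino group, though it differs from compound 3 in a second place as well, and compound 1 at 9380 nM serves as a rough guide. Among the compounds with values here, no measured compound carries the entering group, which leaves the size open.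

A clear step towards a higher number is expected, estimated as a 5.3-fold higher number from compound 3 to compound 4 (0.72 log units; beyond the scatter) in this assay for now. The expected value for compound 4 is 3000 nM (estimated range 700 nM to 12000 nM).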

Compound 4, half-maximal inhibitory concentration: 2560 nM
The estimate for compound 4 lay 1.2-fold (0.07 log units) above the measured number, within the range that was stated.
By their numbers in this assay, from the lowest: compound 3; then compound 4; then compound 1. At a limit, above all of these: compound 2.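

In this assay, ((4-nitrophenyl)carbonyl)oxy in place of diethylamino gives a 4.5-fold higher number from compound 3 to compound 4 (0.65 log units; beyond the scatter). For the compounds shown here, this is the first exact size for a single change at this place, and the first comparison in which diethylamino leaves while the saturated chain carbon stays, so the group on that carbon alone moves the number beyond the scatter, though only modestly for an entering group that brings a six-membered aromatic ring. The earlier step at this place gives only a bound, since compound 2 stands at a limit of the assay and not at a number: the limit of > 10000 nM in this assay, at which 1 of the 4 values shown sits.

With one amine and one ester on this carbon, the compounds shown cannot separate what is lost with diethylamino from what is gained with ((4-nitrophenyl)carbonyl)oxy, and a plain hydroxymethyl group would give the missing reference point. From the compounds shown here alone, it also remains open whether other amines, such as dimethylamino or a cyclic amine like morpholine, match compound 3, and whether an unsubstituted benzoyl ester reads like compound 4 without its nitro group.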